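Swapping the aryl group on the amine: toward a trifluoromethylphenyl

The source may report more compounds than this note shows. Statements on the series, on what has been measured and on what is new or still open speak of the compounds shown alone.

Measured compounds:
- compound 1 `C=CC(=O)Nc1cccc(NC(=O)CSc2nc(Nc3ccccc3F)c3ccccc3n2)c1` gives 9340 nM
- compound 2 `C=CC(=O)Nc1cccc(NC(=O)CSc2nc(Nc3cccc(OC)c3)c3ccccc3n2)c1` gives 34900 nM

Both values come from a functional assay on PC-3 cells (Homo sapiens) for inhibition, read by MTT assay, with a stated time of 72 h; on this read-out lower numbers stand for stronger inhibition and higher numbers for weaker inhibition. Compound 2 stands at the higher of the two numbers, so it is the weaker inhibitor of the pair. Within the data shown here, the one step seen so far, a 3.7-fold higher number from compound 1 to compound 2 (0.57 log units; beyond the scatter), shows that changing the aryl group on the amine can shift the result beyond the scatter.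

Compound 3 `C=CC(=O)Nc1cccc(NC(=O)CSc2nc(Nc3ccc(C(F)(F)F)cc3)c3ccccc3n2)c1` is the next compound, and it differs from compound 2 in that same place: 4-(trifluoromethyl)phenyl in place of 3-methoxyphenyl on a nitrogen on an aromatic ring. Among the measured compounds shown here, the step from compound 1 to compound 2 is the only guide, and it does not involve a trifluoromethylphenyl group, so it says only that this position matters, not in which direction a new aryl group will move the number. With the acceptor of the methoxy group gone and three fluorines entering, the expectation is a modest move back toward the number of compound 1, likely within or near the scatter. For compound 3 the estimated step is a 1.7-fold lower number from compound 2 to compound 3 (0.24 log units; within the scatter), giving an expected value of 20000 nM, with a range from 6000 nM to 70000 nM.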

Compound 3, half-maximal inhibitory concentration: 12500 nM
For compound 3 the middle estimate is 1.6-fold (0.20 log units) above the measured one; measured number inside the range.
By their numbers in this assay, from the lowest: compounds 1 and 3 (each within the scatter of the next); then compound 2.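

Among these compounds, the move to 4-(trifluoromethyl)phenyl in this assay brings a 2.8-fold lower number from compound 2 to compound 3 (0.45 log units; beyond the scatter) and so shows that a change at this place on the nitrogen can lower the number as well as raise it, which the single earlier step could not show. The other comparison gives a 1.3-fold higher number from compound 1 to compound 3 (0.13 log units; within the scatter) and places 2-fluorophenyl and 4-(trifluoromethyl)phenyl level with each other despite their different substituents, leaving compound 2, with its 3-methoxyphenyl, as the weakest inhibitor of the three. Nothing available here explains why the 3-methoxyphenyl compound differs from the other two.

The three aryl groups differ both in their substituent and in where it sits on the ring, so these compounds cannot separate the effect of the group from the effect of its location. From the compounds shown here alone, it also remains open how this position would respond to a phenyl ring carrying a chlorine atom, a nitrile, an amine or a carboxylic acid, and whether any such group would bring the number clearly lower than those of compound 1 and compound 3.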